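Hydroxyethyl for propyl on the amide nitrogen of compound 3

The compounds below may be only part of what the source reports. "The series", "measured", "known", "first", "only" and "open" are said of these compounds alone.

Measured so far:
compound 1 `CCN(Cc1ccc(F)cc1)C(=O)C1CCN(S(=O)(=O)c2ccc3cn[nH]c3c2)CC1` — in a functional assay on CHO cells for positive allosteric modulation of muscarinic acetylcholine receptor M5 (Homo sapiens), read by calcium flux (a higher number here means a larger maximal response, a lower number a smaller maximal response), compound 1 gives 55%
compound 2 `CCN(Cc1ccc(C(F)(F)F)cc1)C(=O)C1CCN(S(=O)(=O)c2ccc3cn[nH]c3c2)CC1` — in this assay compound 2 gives "not determined" (no result reported)
compound 3 `CCCN(Cc1ccccc1C(F)(F)F)C(=O)C1CCN(S(=O)(=O)c2ccc3[nH]ncc3c2)CC1` — in this assay compound 3 gives 94%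

Compound 3 holds the higher of the two numbers that exist in this assay; the nearest entry, compound 1, sits lower by a margin beyond the scatter, and compound 2 contributes no number. Compound 3 differs from compound 1 in more than one place, so the gap between them cannot be tied to a single change.

Compound 4 `O=C(C1CCN(S(=O)(=O)c2ccc3[nH]ncc3c2)CC1)N(CCO)Cc1ccccc1C(F)(F)F` is the next entry to go into this assay. Against compound 3 the change is hydroxy in place of methyl on a saturated chain carbon, two bonds along the chain from an amide-type nitrogen. Among the compounds with values here, no measured pair shows this change, so its effect is unknown from the data. The expectation is a small step downward from compound 3 to compound 4, or none beyond the scatter, as the change is confined to one heavy atom on the chain. For compound 4 the estimate in this assay is 80%, with a range of 55% to 100%, meaning an expected step of a number 14 percentage points lower from compound 3 to compound 4 (beyond the scatter).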

Compound 4, largest response reached (reported as percent of maximum), in percent of the reference or control that the assay uses: 60%
For compound 4 the middle estimate is 20 percentage points above the measured one; the range from low to high includes it.
By their numbers in this assay, from the lowest: compounds 1 and 4 (each within the scatter of the next); then compound 3.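

Within the data shown here, this is the first pair that differs in one place, and it shows that the chain on the amide nitrogen is sensitive to a change of one heavy atom. In this assay, hydroxy in place of methyl on a saturated chain carbon, two bonds along the chain from an amide-type nitrogen, gives a number 34 percentage points lower from compound 3 to compound 4 (beyond the scatter) and so turns propyl into 2-hydroxyethyl at a clear loss of maximal response. Nothing available here accounts for the size of this step.

Going by these compounds, whether the loss is specific to hydroxy remains open: a methoxy, an amine or a carboxylic acid in its place could read differently, and a butyl chain would show whether the chain tolerates extension. One pair also cannot show whether the same change reads alike on other compounds of the series.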